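The source may report more compounds than this note shows. Statements on the series, on what has been measured and on what is new or still open speak of the compounds shown alone.

In an ADME assay on THP-1 cells (Homo sapiens) for cytotoxicity, read by flow cytometry and propidium iodide staining, with a stated time of 72 h (a higher number here means a weaker inhibitor, a lower number a stronger inhibitor), compound 3 `COc1c(-c2ccc(F)cc2)oc2ccc(NC(C)=O)cc2c1=O` gives > 125000 nM, which is a limit of the assay and not a number. Compound 2 `COc1c(-c2ccccc2)oc2ccc(NC(C)=O)cc2c1=O` gives > 125000 nM, also a limit. Compound 1 `CC(=O)Nc1ccc2oc(-c3ccc(C(F)(F)F)cc3)c(O)c(=O)c2c1` gives > 50000 nM, again a limit.

Compound 4 `COc1c(-c2ccc(C(F)(F)F)cc2)oc2ccc(NC(C)=O)cc2c1=O` differs from compound 3 by trifluoromethyl in place of fluoro on an aromatic carbon. Among the measured compounds shown here, the only measured single change, a step that the two limits leave unreadable from compound 2 to compound 3, offers no size to build on. Compound 1 also carries trifluoromethyl, and its result in this assay gives no measured number either. No step beyond the usual scatter is therefore expected, and another limit is the likeliest result. The estimated step is an at least 1.0-fold lower number from compound 3 to compound 4 (0.01 log units; that floor lies within the scatter). For compound 4, the expected value is 120000 nM, with an estimated range from 50000 nM to 250000 nM.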

Compound 4, half-maximal inhibitory concentration: > 125000 nM
Compound 4 was reported as a limit; the forecaster's own chance of this, stated with the estimate: 85%; at least 1.0-fold (0.01 log units) between middle value and limit.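

Among the compounds shown here, compound 4 gives a limit of the assay and not a number, like compound 1, compound 2 and compound 3, and no step among them can be read. The compounds shown leave open whether any of these changes alters cytotoxicity at all.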